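Swapping Methyl for Bromomethyl on a Potent Amide

This account rests on a few compounds, and the source may have more. Where it says the series, first, only, none or still open, it means among the compounds named here.

Of the compounds shown here, three share one core and have been tested in an in vitro assay on UC11MG cells for binding affinity to Substance-P receptor (Homo sapiens), read by radioligand binding; on this read-out lower numbers stand for stronger inhibition and higher numbers for weaker inhibition. Compound 1 `O=C(NCc1cc(C(F)(F)F)cc(C(F)(F)F)c1)c1cnc2ccccc2c1-c1ccccc1` reaches only the limit of this assay, > 1000 nM, and that value is a limit rather than a number. Compound 3 `O=C(NCc1cc(C(F)(F)F)cc(C(F)(F)F)c1)c1c(CCl)nc2ccccc2c1-c1ccccc1` gives 26 nM. Compound 2 `Cc1nc2ccccc2c(-c2ccccc2)c1C(=O)N(C)Cc1cc(C(F)(F)F)cc(C(F)(F)F)c1`, which carries a methyl on the core and a methyl on the amide nitrogen, gives 3.1 nM, the lowest of the two numbers shown. The step of an at least 38-fold lower number from compound 1 to compound 3 (1.58 log units; beyond the scatter) shows that adding a halogenated one-carbon group to the core goes with a much lower number, though compound 1 sits at a limit (the limit of > 1000 nM in this assay, at which 1 of the 3 values shown sits), so the true size of that step is not known.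

Compound 4 `CN(Cc1cc(C(F)(F)F)cc(C(F)(F)F)c1)C(=O)c1c(CBr)nc2ccccc2c1-c1ccccc1` differs from compound 2 by bromo in place of hydrogen on a saturated chain carbon bound to an aromatic carbon. Within the data shown here, no measured pair isolates this change: the step from compound 1 to compound 3 adds a whole chloromethyl where hydrogen stood, and compounds 2 and 3 differ in two places at once. The expectation is therefore a step no larger than the usual scatter, a 1.3-fold higher number from compound 2 to compound 4 (0.11 log units; within the scatter), so compound 4 is estimated at 4 nM, between 1.5 nM and 15 nM.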

Compound 4, half-maximal inhibitory concentration: 52 nM
The estimate for compound 4 lay 13-fold (1.11 log units) below the measured number; the measured number lies above the stated range.
By their numbers in this assay, from the lowest: compound 2; then compounds 3 and 4 (each within the scatter of the next). At a limit, above all of these: compound 1.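

Methyl to bromomethyl gives a 17-fold higher number from compound 2 to compound 4 (1.22 log units; beyond the scatter) in this assay, so a single added bromine on a saturated chain carbon bound to an aromatic carbon is enough to move the number well beyond the scatter. The earlier compounds shown here showed only a halogenated one-carbon group set against hydrogen, and that comparison rests on a limit; this pair keeps the methyl on the amide nitrogen fixed and shows that, set against a plain methyl, the bromine goes with a higher number. Nothing measured here gives a reason for this step.

On these data alone, the steps among compounds that differ in two places cannot be read, so the part played by the amide methyl stays open. Also open, as far as these compounds go, is how chloromethyl on the methylated amide, or a hydroxymethyl, an aminomethyl or an ethyl group, would read at this position.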